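Urea series: removal of trifluoromethyl from compound 3

The compounds below may be only part of what the source reports. "The series", "measured", "known", "first", "only" and "open" are said of these compounds alone.

Compound 1 `CC(C)(C)NC(=O)Nc1nc2ccc(C#N)cc2s1` gives 2780 nM in a functional assay (thoracic aorta, Rattus norvegicus, strain Wistar); on this read-out lower numbers stand for an effect already at smaller amounts and higher numbers for an effect only at larger amounts of compound. Compound 2 `N#Cc1ccc(NC(=O)Nc2nc3c(s2)CCCC3)cc1` reaches only the limit > 100000 nM in this assay. Compound 3 `O=C(Nc1ccc(Cl)c(C(F)(F)F)c1)Nc1nc2c(s1)CCCC2` likewise gives only the limit > 100000 nM in this assay, a limit and not a number. Compound 3 therefore stands at the limit of > 100000 nM in this assay, at which 2 of the 3 values shown sit, with no measured number of its own. Compound 4 `O=C(Nc1ccc(Cl)cc1)Nc1nc2c(s1)CCCC2` differs from compound 3 by hydrogen in place of trifluoromethyl on an aromatic carbon, in words hydrogen in place of trifluoromethyl on an aromatic carbon. Within the data shown here, no step between two measured compounds is on record in this set. In this assay the step from compound 3 to compound 4 is expected to be a number no higher from compound 3 to compound 4 (the limit leaves the size open), none beyond the scatter. For compound 4 the estimate in this assay is 100000 nM, within 20000 nM to 300000 nM, most probably reported again only as a limit.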

Compound 4, half-maximal effective concentration: > 100000 nM
Compound 4: only a limit was reported; the forecaster's own chance of this, stated with the estimate: 75%; the middle value sits exactly at the limit.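

In this assay, among these compounds, no step to compound 4 can be read from compound 2 or compound 3, since all three stand only as limits: the limit of > 100000 nM in this assay, at which 3 of the 4 values shown sit. Going by these compounds, whether hydrogen in place of trifluoromethyl or chloro in place of cyano changes the effect in this assay at all stays open.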